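Sulfonyl in place of benzyl on the shared core

The source may hold more compounds than are shown below. What is called first, only, known or untested is meant among the compounds shown, and "the series" means these compounds.

Among the measured compounds shown here, in an ADME assay on MT4 cells (Homo sapiens) for cytotoxicity (a higher number here means that more compound is tolerated, a lower number that less compound is tolerated), compound 2 `COC(=O)c1ccc(NC(=O)CSc2nc3ccc(Cl)cc3n2Cc2cc(C)cc(C)c2)c(Cl)c1` gives 105000 nM, within the scatter of compound 1 `Cc1cc(C)cc(S(=O)(=O)n2c(SCC(=O)Nc3ccccc3Br)nc3ccc(Cl)cc32)c1` at 145000 nM, the only other measured compound. Compound 3 `COC(=O)c1ccc(NC(=O)CSc2nc3ccc(Cl)cc3n2S(=O)(=O)c2cc(C)cc(C)c2)c(Cl)c1` carries (3,5-dimethylphenyl)sulfonyl in place of 3,5-dimethylbenzyl on an aromatic nitrogen. For the measured compounds named here, no measured pair isolates this change. With compound 1 at 145000 nM and compound 2 at 105000 nM, no step beyond the scatter is expected in this assay. The estimated step of a 1.1-fold higher number from compound 2 to compound 3 (0.06 log units; within the scatter) stays within the scatter. For compound 3 the expected value is 120000 nM, with an estimated range of 60000 nM to 220000 nM.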

Compound 3, half-maximal cytotoxic concentration: >= 130000 nM
Compound 3: a limit, no number; the forecaster's own chance of this, stated with the estimate: 15%; middle value at least 1.0-fold (0.03 log units) from the limit.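

In this assay compound 3 is a limit and not a number: the limit of >= 130000 nM in this assay, at which 1 of the 3 values shown sits. Among the compounds shown here, this is the first pair that isolates (3,5-dimethylphenyl)sulfonyl in place of 3,5-dimethylbenzyl on an aromatic nitrogen, and it gives an at least 1.2-fold higher number from compound 2 to compound 3 (0.09 log units; that floor lies within the scatter), so the swap shows no loss of tolerated compound. The step between compound 1 and compound 3 cannot be read.

As far as these compounds go, how far the true value of compound 3 lies beyond the limit stays open. Also open, from the compounds shown here alone, is whether a carbonyl or a longer chain in place of the sulfonyl on this nitrogen would keep the number in this range.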